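Working notes on a small series and one pending analogue

A few compounds are considered here, and "the series" means these few. Any claim that something is new, unique, unknown or untested is made for them only; others in the source may bear on it.

Measured in a functional assay on CHO cells with adenosine receptor A1 (Homo sapiens) as the target, read by cAMP accumulation and immunoassay, with a stated time of 6 min, tested at 0.01 uM; on this read-out lower numbers stand for a stronger effect and higher numbers for a weaker effect at the one concentration tested:
compound 1, `Nc1scc(CN2CCN(c3cccnc3)CC2)c1C(=O)c1ccc(Cl)cc1`, gives 3.2%
compound 2, `Nc1scc(CN2CCC(c3ccc(Cl)cc3)CC2)c1C(=O)c1ccc(Cl)cc1`, gives 0%
compound 3, `Nc1scc(CN2CCN(c3cccc(F)c3)CC2)c1C(=O)c1cccc(C(F)(F)F)c1`, gives -11%

Compound 1 holds the highest of the three numbers in this assay. Its nearest neighbour is compound 2, whose number is within the usual scatter of that of compound 1, so no order between these two is claimed. Compound 3 lies furthest away, with a number beyond the scatter below that of compound 1, meaning a stronger effect at the single concentration tested. All three numbers sit close to the zero line of the read-out.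

The next analogue, compound 4, `Nc1scc(CN2CCN(CCCc3ccc(Cl)cc3)CC2)c1C(=O)c1ccc(Cl)cc1`, is to be measured in this assay. Against compound 1 the structural difference is 3-(4-chlorophenyl)propyl in place of pyridin-3-yl on an amine nitrogen in a ring.

Among the compounds with values here, no pair of measured compounds differing in a single place is available, so nothing measured gives the size of such a step directly. What the series does show is that compound 2, which also carries a chlorophenyl group, gives 0%, a number within the scatter of compound 1. On that basis the step from compound 1 to compound 4 is expected to be small, a number 3.2 percentage points lower from compound 1 to compound 4 (within the scatter), none beyond the scatter in either direction. For compound 4 the expected value in this assay is 0%, estimated to fall between -15% and 15%.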

Compound 4, a percentage reported as activity, at one concentration (the size of the read-out at that concentration, not a potency): 0%
Compound 4: middle estimate and measured number agree at the digits printed, within the range that was stated.
By their numbers in this assay, from the lowest: compound 3; then compounds 2, 4 and 1 (each within the scatter of the next).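

In this assay, within the data shown here, the exchange of pyridin-3-yl for 3-(4-chlorophenyl)propyl on an amine nitrogen in a ring gives a number 3.2 percentage points lower from compound 1 to compound 4 (within the scatter), the first step that can be read at a single place. This position therefore takes a substituent of 10 heavy atoms in place of one of 6, and a six-membered aromatic ring of carbon only in place of one with 1 hetero atom, with 1 hydrogen-bond acceptor fewer, and none of this moves the number beyond the scatter at the one concentration tested. Nothing at hand bears on why this step has the size it has.

From the compounds shown here alone, whether this tolerance holds for other substituents on the same nitrogen remains open, for example a benzyl group, a longer chain than propyl, or a chain ending in a carboxylic acid or a primary amine. Among these compounds, also open is whether the step stays within the scatter at other concentrations, since a single concentration gives no potency for either compound.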